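Changing one aryl group on a weak antiproliferative compound

A few compounds are considered here, and "the series" means these few. Any claim that something is new, unique, unknown or untested is made for them only; others in the source may bear on it.

Among the measured compounds shown here, in a functional assay on CNE-2 cells (Homo sapiens) for antiproliferative activity, read by sulforhodamine B assay, with a stated time of 48 h (a higher number here means a weaker inhibitor, a lower number a stronger inhibitor), three related compounds have numbers so far. Compound 1 (`COc1cc(OC)c(C=C(C(=O)/C=C/c2cccc(OC)c2OC)C(=O)/C=C/c2cccc(OC)c2OC)c(OC)c1`) gives 630 nM, compound 2 (`COc1ccc(C=C(C(=O)/C=C/c2cccc(OC)c2OC)C(=O)/C=C/c2cccc(OC)c2OC)cc1O`) gives 220 nM, and compound 3 (`COc1ccc(/C=C/C(=O)C(=Cc2ccc(O)c(F)c2)C(=O)/C=C/c2ccc(OC)cc2OC)c(OC)c1`) gives 2830 nM. Compound 3 has the highest number of the three, which makes it the weakest inhibitor of this small set.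

Compound 4 (`COc1ccc(/C=C/C(=O)C(=Cc2cc(OC)c(O)c(OC)c2)C(=O)/C=C/c2ccc(OC)cc2OC)c(OC)c1`) has not been measured yet. It has 4-hydroxy-3,5-dimethoxyphenyl in place of the 3-fluoro-4-hydroxyphenyl of compound 3, on a double-bonded chain carbon bound to a double-bonded chain carbon: 4-hydroxy-3,5-dimethoxyphenyl in place of 3-fluoro-4-hydroxyphenyl on a double-bonded chain carbon bound to a double-bonded chain carbon.

One measured change sits at this same place, where 3-hydroxy-4-methoxyphenyl replaces 2,4,6-trimethoxyphenyl: a 2.9-fold lower number from compound 1 to compound 2 (0.46 log units; beyond the scatter). This shows that a change here can move the number beyond the scatter. It is only a loose guide, however, since it swaps different groups and compound 1 and compound 2 also differ from compound 3 elsewhere in the structure. For the measured compounds named here, no measured step tests the present swap directly.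

A similarly modest move towards a stronger inhibitor is expected, though with little certainty. The estimated step is expected to be a 2.0-fold lower number from compound 3 to compound 4 (0.31 log units; beyond the scatter). The estimated value for compound 4 is 1400 nM, with an expected range of 450 nM to 4000 nM.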

Compound 4, half-maximal inhibitory concentration: 850 nM
Estimate against measurement, compound 4: 1.6-fold (0.22 log units) above; the measured number falls inside the stated range.
By their numbers in this assay, from the lowest: compound 2; then compounds 1 and 4 (each within the scatter of the next); then compound 3.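

In this assay, putting 4-hydroxy-3,5-dimethoxyphenyl in place of 3-fluoro-4-hydroxyphenyl gives a 3.3-fold lower number from compound 3 to compound 4 (0.52 log units; beyond the scatter) on a double-bonded chain carbon bound to a double-bonded chain carbon. This is a second pair of compounds in which a change at this place moves the number beyond the scatter, and the pair has different outer aryl groups from the earlier pair, which showed a 2.9-fold lower number from compound 1 to compound 2 (0.46 log units; beyond the scatter) in the same direction. The two steps also differ in one useful way: the stronger inhibitor gained methoxy groups on this aryl group in the new step but had fewer of them in the earlier one, so the number of methoxy groups alone does not set the direction across these four compounds, and no measurement shown explains the drop.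

It remains open whether the loss of fluorine or the gain of the methoxy groups matters more, since no compound shown has only one of these changes. Also open, as far as these compounds go, is how this place would respond to an aryl group bearing an amine or a carboxylic acid, and whether the present swap would give a similar step on the core of compound 1.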